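Acetyl on the Hydroxy Group of a Cyclopentenone Core

The compounds below may be only part of what the source reports. "The series", "measured", "known", "first", "only" and "open" are said of these compounds alone.

The three measured compounds were tested in an ADME assay on HT-29 cells (Homo sapiens) for cytotoxicity, read by MTT assay, with a stated time of 72 h; on this read-out higher numbers stand for weaker inhibition and lower numbers for stronger inhibition. Compound 1 `COc1ccc(C2=C(c3cc(OC)c(OC)c(OC)c3)C(=O)C(OC(C)=O)C2)cc1` carries an acetoxy group on its saturated ring carbon, and in this assay compound 1 gives < 1 ug/mL, which is a limit of the assay and not a number. Compound 2 `COc1ccc(C2=C(c3cc(OC)c(OC)c(OC)c3)C(=O)C(O)C2)cc1` carries the free hydroxy group instead, and in this assay compound 2 gives < 1 ug/mL, again a limit of the assay. The change between them is acetyl in place of hydrogen on an oxygen on a saturated carbon. Because both values sit at the limit of < 1 ug/mL in this assay, at which 2 of the 3 values shown sit, the step that the two limits leave unreadable from compound 2 to compound 1.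

Compound 3 `COc1cc(C2=C(c3cc(C)c(OC)c(C)c3)C(O)CC2=O)cc(OC)c1OC` has a different core; how it differs from compound 2 is not broken down here. In this assay compound 3 gives > 100 ug/mL, which is a limit of the assay and not a number, so it sits at the limit of > 100 ug/mL in this assay, at which 1 of the 3 values shown sits.

Compound 4 `COc1cc(C2=C(c3cc(C)c(OC)c(C)c3)C(OC(C)=O)CC2=O)cc(OC)c1OC` is not yet measured. It differs from compound 3 by acetyl in place of hydrogen on an oxygen on a saturated carbon, the same change that separates compound 2 from compound 1, made at the same place. Compound 4 is expected to give 100 ug/mL, within a range from 30 ug/mL to 300 ug/mL. The step of a number no higher from compound 3 to compound 4 (the limit leaves the size open) is estimated as small, and this rests on the fact that a step that the two limits leave unreadable from compound 2 to compound 1 could not be sized at all, so no reason appears for expecting the acetyl to move the value far from where compound 3 stands.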

Compound 4, half-maximal inhibitory concentration: > 100 ug/mL
Compound 4: a limit, no number; the forecaster's own chance of this, stated with the estimate: 70%; the middle value lies on the limit itself.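

In this assay compound 4 gives > 100 ug/mL, which is a limit of the assay and not a number. Compound 3 sits at the same limit, so no step can be read between compound 3 and compound 4: the limit of > 100 ug/mL in this assay, at which 2 of the 4 values shown sit. The compounds shown leave open the size of the change from hydroxy to acetoxy in either pair, as all four values are limits.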